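This account rests on a few compounds, and the source may have more. Where it says the series, first, only, none or still open, it means among the compounds named here.

Measured so far in a functional assay on Huh-7 cells (Homo sapiens) for inhibition, read by CCK-8 assay, with a stated time of 72 h; a higher number here means a weaker inhibitor, a lower number a stronger inhibitor:
- compound 1 `O=C(/C=C/c1cccnc1)NCCCCCCCc1cccc(S(=O)(=O)Nc2ccccc2)c1` gives 138 nM
- compound 2 `Cc1ccc(NS(=O)(=O)c2cccc(CCCCCCNC(=O)/C=C/c3cccnc3)c2)cc1` gives 6.92 nM

Of these two compounds, compound 2 has the lower number and so is the stronger inhibitor, and the gap to compound 1 lies beyond the usual scatter. The two also differ in more than one place, so their values do not isolate the effect of any single change.

The next compound to be tested is compound 3 `O=C(/C=C/c1cccnc1)NCCCCCCc1cccc(S(=O)(=O)Nc2ccc(F)c(Cl)c2)c1`, which carries 3-chloro-4-fluorophenyl in place of 4-methylphenyl on a sulfonamide nitrogen. Among the measured compounds shown here, no pair of measured compounds shows a change at this place, so any expectation for this assay is loose. It starts from compound 2 at 6.92 nM, and a small move toward a higher number seems most likely, not clearly beyond the scatter. The expected size of this change is a 1.4-fold higher number from compound 2 to compound 3 (0.16 log units; within the scatter). For compound 3 the estimated value is 10 nM, with an expected range from 2.5 nM to 40 nM.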

Compound 3, half-maximal inhibitory concentration: 39.4 nM
Compound 3: the middle estimate sits 3.9-fold (0.60 log units) below what was measured, and the stated range covers the measured number.
By their numbers in this assay, from the lowest: compound 2; then compound 3; then compound 1.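

In this assay, among the compounds shown here, the group on the sulfonamide nitrogen proves to matter: 3-chloro-4-fluorophenyl in place of 4-methylphenyl gives a 5.7-fold higher number from compound 2 to compound 3 (0.76 log units; beyond the scatter), the first reading of a single change, as compound 1 and compound 2 differ in more than one place. Both groups are six-membered aromatic rings of carbon only, with no hydrogen-bond donors or acceptors and no net charge, so this position responds to a change in what the ring carries even when those counts stay the same. No measurement available here explains the direction or size of this step.

The step removes a methyl group and adds chlorine and fluorine together, so the compounds shown leave open whether the loss of the methyl, the chlorine or the fluorine accounts for it. As far as these compounds go, it also remains open how a methoxyphenyl group or a pyridine ring on the sulfonamide nitrogen would read against compound 2 with the rest of the structure unchanged.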